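Inverting Two Ring Stereocentres in Compound 1

The source may report more compounds than this note shows. Statements on the series, on what has been measured and on what is new or still open speak of the compounds shown alone.

Measured so far:
Compound 1 `COc1cc([C@@H]2Oc3c(OC)cc(CCCO)cc3[C@H]2CO[C@@H]2O[C@@H](C)[C@H](O)[C@@H](O)[C@H]2O)cc(OC)c1O` gives > 10000 nM in a functional assay on HCT-15 cells (Homo sapiens) for cytotoxicity, read by sulforhodamine B assay; a lower number here means a stronger inhibitor, a higher number a weaker inhibitor; this value is a limit of the assay, not a number.
Compound 2 `COc1cc(C[C@@H]2CO[C@@H](c3ccc(O)c(OC)c3)[C@@H]2CO[C@@H]2O[C@@H](C)[C@H](O)[C@@H](O)[C@H]2O)ccc1O` gives > 10000 nM in this assay; this value too is a limit of the assay, not a number.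

Compound 1 therefore stands at the limit rather than at a measured point, and the limit of > 10000 nM in this assay, at which 2 of the 2 values shown sit, shows that every value recorded in this set sits at that same limit. Going by the values given here, no step between two measured compounds exists here, so no measured step can guide what a change in configuration does.

Compound 3 `COc1cc([C@H]2Oc3c(OC)cc(CCCO)cc3[C@@H]2CO[C@@H]2O[C@@H](C)[C@H](O)[C@@H](O)[C@H]2O)cc(OC)c1O` differs from compound 1 as follows: the two compounds have the same atoms and bonds and differ only in configuration as drawn: 2 of 7 stereo elements differ; a stereocentre at a saturated ring carbon is drawn R in compound 1 and S in compound 3; a stereocentre at a saturated ring carbon is drawn S in compound 1 and R in compound 3. Among the compounds with values here, no measured step relates compounds of this kind, so the expectation rests only on where compound 1 stands. Since compound 1 sits at the limit, compound 3 is expected to sit there as well, with any difference not beyond the usual scatter. Compound 3 is estimated at 20000 nM, with a range from 8000 nM to 60000 nM. The step that the limit leaves unreadable from compound 1 to compound 3 is expected to be negligible.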

Compound 3, half-maximal inhibitory concentration: > 10000 nM
Compound 3: no number, only a limit; the forecaster's own chance of this, stated with the estimate: 85%; the middle value does not contradict the limit.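

Going by these compounds alone, compound 1 and compound 3 differ only in configuration at two ring stereocentres, but both values are limits in this assay, not numbers, so no step between them can be read. The compounds shown leave open whether either configuration has any measurable effect on potency, since none gives a number: the limit of > 10000 nM in this assay, at which 3 of the 3 values shown sit.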